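Chloro for Methyl on the Quinone-Bearing Pyrazole

The source may hold more compounds than are shown below. What is called first, only, known or untested is meant among the compounds shown, and "the series" means these compounds.

Measured so far:
Compound 1 `NS(=O)(=O)c1ccc(-n2nc(-c3ccc(Cl)cc3)cc2-c2cc(O)ccc2O)cc1`: 12000 nM
Compound 2 `Cc1ccc(-c2cc(C3=CC(=O)C=CC3=O)n(-c3ccc(S(N)(=O)=O)cc3)n2)cc1`: 55600 nM

In a functional assay on cells (Cancer cell lines, Homo sapiens) for cytotoxicity, read by sulforhodamine B assay, with a stated time of 48 h (on this read-out higher numbers stand for weaker inhibition of growth and lower numbers for stronger inhibition of growth), compound 2 gives 55600 nM, the highest of the two numbers; the nearest, compound 1, gives 12000 nM, a gap beyond the scatter. Compound 3 `NS(=O)(=O)c1ccc(-n2nc(-c3ccc(Cl)cc3)cc2C2=CC(=O)C=CC2=O)cc1` differs from compound 2 by chloro in place of methyl on an aromatic carbon. Going by the values given here, no measured pair shows this change alone, so its effect is unknown; compound 1 also carries chloro but differs elsewhere as well. For compound 3 a small step toward a lower number is expected, a 1.6-fold lower number from compound 2 to compound 3 (0.20 log units; within the scatter), about 35000 nM, within 12000 nM to 90000 nM.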

Compound 3, concentration for 50% growth inhibition: 23100 nM
Compound 3: middle estimate off by 1.5-fold (0.18 log units), on the high side, within the range that was stated.
By their numbers in this assay, from the lowest: compounds 1 and 3 (each within the scatter of the next); then compound 2.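

In this assay the change from 4-methylphenyl to 4-chlorophenyl, alone, gives a 2.4-fold lower number from compound 2 to compound 3 (0.38 log units; beyond the scatter) and so shows that this position responds to the swap, though modestly. Putting the six-membered non-aromatic ring in place of the six-membered aromatic ring gives a 1.9-fold higher number from compound 1 to compound 3 (0.28 log units; within the scatter) and so shows no clear difference between those two groups here. Nothing at hand explains either step. Still open, from the compounds shown here alone, is how an amine or a methoxy group would read at this position. Also open, going by these compounds, is whether chloro in place of methyl gives a similar step on the core of compound 1.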